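A few compounds are considered here, and "the series" means these few. Any claim that something is new, unique, unknown or untested is made for them only; others in the source may bear on it.

Measured compounds:
Compound 1 `COc1ccc([C@@H]2C/C(=N/OCc3cn(-c4ccccc4CO)nn3)c3cc(CC=C(C)C)c(OC)cc3O2)cc1`: 100%
Compound 2 `COc1cc2c(cc1CC=C(C)C)C(=O)C[C@@H](c1ccc(Oc3ccc(F)cc3)cc1)O2`: 27%
Compound 3 `COc1ccc([C@@H]2C/C(=N/OCc3cn(-c4ccc(C#N)cc4)nn3)c3cc(CC=C(C)C)c(OC)cc3O2)cc1`: 42%

In a functional assay on A549 cells (Homo sapiens) for inhibition, read by sulforhodamine B assay, with a stated time of 48 h, tested at 50 uM (a lower number here means less inhibition of growth, a higher number more inhibition of growth at the concentration tested), compound 2 gives the lowest of the three numbers; compound 3 stands nearest to it and compound 1 furthest, both beyond the scatter. Among the compounds with values here, the only measured step, a number 58 percentage points lower from compound 1 to compound 3 (beyond the scatter), concerns a substituent on an aromatic nitrogen in the oxime-linked part of the core of compound 1, a position that compound 2 does not carry. Compound 4 `CCCCOc1ccc([C@@H]2CC(=O)c3cc(CC=C(C)C)c(OC)cc3O2)cc1` differs from compound 2 by butyl in place of 4-fluorophenyl on an oxygen on an aromatic ring. Within the data shown here, no measured step touches this oxygen, so the data give no direction for the change. The step of no change at the digits printed from compound 2 to compound 4 (within the scatter) is therefore expected to stay within the scatter. Compound 4 is estimated to give 27%, between 5% and 55%.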

Compound 4, percent growth inhibition at one concentration: 37%
The estimate for compound 4 lay 10 percentage points below the measured number; measured number inside the range.
By their numbers in this assay, from the lowest: compounds 2, 4 and 3 (each within the scatter of the next, the first and the last beyond it); then compound 1.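

In this assay, within the data shown here, the oxygen on the aromatic ring is touched for the first time, with a number 10 percentage points higher from compound 2 to compound 4 (within the scatter) when butyl replaces 4-fluorophenyl. At this position, then, the assay does not separate the two groups, even though the six-membered aromatic ring leaves with the swap. Nothing measured on these compounds accounts for this result. Open, as far as these compounds go, is how a longer chain, or an amine or a carboxylic acid carried on this oxygen, would read, and whether butyl reads the same in compounds with the oxime-linked part.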